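The compounds below may be only part of what the source reports. "The series", "measured", "known", "first", "only" and "open" are said of these compounds alone.

Compound 1 `COc1ccc(/C=C2\CNC/C(=C\c3ccc(OC)c(OC)c3)C2=O)cc1OC`: 10300 nM
Compound 2 `COc1cc(/C=C2\CNC/C(=C\c3cc(OC)c(OC)c(OC)c3)C2=O)cc(OC)c1OC`: 4000 nM

Among the measured compounds shown here, in a functional assay on NCI-H1975 cells (Homo sapiens) for cytotoxicity, read by MTT assay, with a stated time of 72 h (on this read-out lower numbers stand for stronger inhibition and higher numbers for weaker inhibition), compound 2 gives 4000 nM, the lower of the two numbers so far, and the gap to compound 1 lies beyond the usual scatter. Compound 3 `COc1cc(/C=C2\CN(C)C/C(=C\c3cc(OC)c(OC)c(OC)c3)C2=O)cc(OC)c1OC` has methyl in place of hydrogen on an amine nitrogen in a ring of compound 2: methyl in place of hydrogen on an amine nitrogen in a ring. For the measured compounds named here, no measured pair shows this change, so the expectation is uncertain, and no step beyond the scatter is expected in this assay. The expected result is a 1.1-fold lower number from compound 2 to compound 3 (0.06 log units; within the scatter). For compound 3 the estimated value is 3500 nM, with an expected range of 1300 nM to 9500 nM.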

Compound 3, half-maximal inhibitory concentration: 1000 nM
For compound 3 the middle estimate is 3.5-fold (0.54 log units) above the measured one; the whole stated range lies above it.
By their numbers in this assay, from the lowest: compound 3; then compound 2; then compound 1.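

In this assay the amine nitrogen in the ring proves to be a place where a single small change counts. Methyl in place of hydrogen there gives a 4.0-fold lower number from compound 2 to compound 3 (0.60 log units; beyond the scatter) and is the first step shown between compounds that differ in one place. Nothing measured here explains why the number falls. The compounds shown leave open whether a longer chain on this nitrogen, such as ethyl or benzyl, or an acetyl group would lower the number further. From the compounds shown here alone, whether methyl would give a similar step on the core of compound 1 also remains open.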